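This account rests on a few compounds, and the source may have more. Where it says the series, first, only, none or still open, it means among the compounds named here.

In a functional assay on SK-MEL-2 cells (Homo sapiens) for cytotoxicity, read by sulforhodamine B assay (a lower number here means that less compound is needed, a higher number that more compound is needed for the effect), compound 1 `O=C1CC(c2ccccc2)Nc2ccccc21` gives 0.13 ug/mL and compound 2 `COc1cccc(C2CC(=O)c3ccccc3N2)c1` gives 0.2 ug/mL. With only these two numbers available, compound 2 stands level with compound 1 within the scatter. Compound 3 `COc1cccc(C2CC(=O)c3cc(N4CCCC4)ccc3N2)c1` differs from compound 2 by pyrrolidin-1-yl in place of hydrogen on an aromatic carbon, with pyrrolidin-1-yl in place of hydrogen on an aromatic carbon of the six-membered aromatic ring of carbon only, part of a fused or bridged system of two rings. Going by the values given here, the sole measured step is a 1.5-fold higher number from compound 1 to compound 2 (0.19 log units; within the scatter), methoxy in place of hydrogen on an aromatic carbon. Among the compounds with values here, it concerns another group at another place, so it bears only weakly on this change, and no measured step shows the effect of pyrrolidin-1-yl. A modest move towards a lower number in this assay is therefore only a tentative expectation. The expected change is a 2.5-fold lower number from compound 2 to compound 3 (0.40 log units; beyond the scatter). For compound 3 the estimated value is 0.08 ug/mL, with an expected range from 0.008 ug/mL to 0.5 ug/mL.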

Compound 3, concentration for half-maximal effect: 0.016 ug/mL
For compound 3 the middle estimate is 5.0-fold (0.70 log units) above the measured one; the range from low to high includes it.
By their numbers in this assay, from the lowest: compound 3; then compounds 1 and 2 (each within the scatter of the next).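

In this assay the step of a 13-fold lower number from compound 2 to compound 3 (1.10 log units; beyond the scatter) shows that this aromatic carbon, meta to a fused ring and para to a fused ring, is open to substitution, and that pyrrolidin-1-yl here goes with a large change in the number. Going by these compounds alone, the only earlier step, a 1.5-fold higher number from compound 1 to compound 2 (0.19 log units; within the scatter) for methoxy at another place, gave no sign of a change of this size. No measurement available explains the size of this step.

Going by these compounds, whether the step needs the whole five-membered ring or only a nitrogen on this carbon stays open, and dimethylamino, piperidin-1-yl or morpholin-4-yl at the same carbon would separate these readings. Also open, on these data alone, are whether pyrrolidin-1-yl has the same effect on the other carbons of this ring and whether it does so without the methoxy group.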